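The source may report more compounds than this note shows. Statements on the series, on what has been measured and on what is new or still open speak of the compounds shown alone.

Measured compounds:
- compound 1, `CCCCCCCn1cc(COC[C@@H]2OC[C@H](N)[C@@H]2O)nn1` — > 128000 nM in a functional assay on MCF7 cells (Homo sapiens) for antiproliferative activity, read by MTT assay, with a stated time of 48 h; on this read-out lower numbers stand for stronger inhibition and higher numbers for weaker inhibition
- compound 2, `CCCCCCCCCn1cc(COC[C@@H]2OC[C@H](N)[C@@H]2O)nn1` — 12400 nM
- compound 3, `CCCCCCCCCCCCCCn1cc(COC[C@@H]2OC[C@H](N)[C@@H]2O)nn1` — 1850 nM

The three share one core and differ only in the alkyl group on the aromatic nitrogen. For compound 1 the value is a limit of the assay, not a number (the limit of > 128000 nM in this assay, at which 1 of the 3 values shown sits). Compound 2 gives 12400 nM and compound 3 gives 1850 nM. From compound 1 to compound 2 the change is ethyl in place of hydrogen on a saturated chain carbon, seven bonds along the chain from an aromatic nitrogen, and it brought an at least 10-fold lower number from compound 1 to compound 2 (1.01 log units; beyond the scatter). From compound 1 to compound 3 the change is heptyl in place of hydrogen on a saturated chain carbon, seven bonds along the chain from an aromatic nitrogen, with an at least 69-fold lower number from compound 1 to compound 3 (1.84 log units; beyond the scatter); between compound 2 and compound 3 the step is a 6.7-fold lower number from compound 2 to compound 3 (0.83 log units; beyond the scatter).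

Compound 4, `CCCCCCCCCCCCCCCCn1cc(COC[C@@H]2OC[C@H](N)[C@@H]2O)nn1`, is not yet measured. Its difference from compound 3 is ethyl in place of hydrogen on a saturated chain carbon, ten or more bonds along the chain from an aromatic nitrogen. This is the same kind of change as from compound 1 to compound 2, but the place along the chain is not the same, as the two differences show. The measured step from compound 1 to compound 2 was an at least 10-fold lower number from compound 1 to compound 2 (1.01 log units; beyond the scatter), yet it started from a limit, and the later step from compound 2 to compound 3 is smaller per added carbon. The expected step from compound 3 to compound 4 is therefore a 1.9-fold lower number from compound 3 to compound 4 (0.27 log units; within the scatter), resting on compound 2 at 12400 nM and compound 3 at 1850 nM. Compound 4 is estimated at 1000 nM, with the expected range 400 nM to 2600 nM.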

Compound 4, half-maximal inhibitory concentration: 3300 nM
For compound 4 the middle estimate is 3.3-fold (0.52 log units) below the measured one; the whole stated range lies below it.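

In this assay, ethyl in place of hydrogen does not carry a fixed gain from one chain length to the next, since a 1.8-fold higher number from compound 3 to compound 4 (0.25 log units; within the scatter) stands against the earlier step at the shorter chain: the same change on two cores in this assay, an at least 10-fold lower number (1.01 log units; beyond the scatter) from compound 1 to compound 2 and a 1.8-fold higher number (0.25 log units; within the scatter) from compound 3 to compound 4, at least 18-fold (1.26 log units) apart, beyond the scatter of two such steps

Longer additions differ in the same way, with a 3.8-fold lower number from compound 2 to compound 4 (0.57 log units; beyond the scatter) and an at least 38-fold lower number from compound 1 to compound 4 (1.58 log units; beyond the scatter) set against the corresponding steps from the shorter chains: the same change on two cores in this assay, an at least 69-fold lower number (1.84 log units; beyond the scatter) from compound 1 to compound 3 and a 3.8-fold lower number (0.57 log units; beyond the scatter) from compound 2 to compound 4, at least 18-fold (1.26 log units) apart, beyond the scatter of two such steps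

Compound 1 sits at a limit of the assay and not at a number, so each step from it gives only a bound on its size, and the series shows that step size depends on the starting chain but not how large the steps from compound 1 really are: the limit of > 128000 nM in this assay, at which 1 of the 4 values shown sits.

The compounds shown leave open whether a longer chain than that of compound 4 would keep the read-out level or raise it, since compound 3 and compound 4 lie within the scatter of each other and the two points fix no trend. Also open, as far as these compounds go, is how a chain ending in a carboxylic acid, or an acetamide in place of the amine on the shared core, would read out.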